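The source may hold more compounds than are shown below. What is called first, only, known or untested is meant among the compounds shown, and "the series" means these compounds.

Measured in a functional assay on Caco-2 cells (Homo sapiens) for cytotoxicity, read by MTT assay, with a stated time of 48 h; on this read-out lower numbers stand for stronger inhibition and higher numbers for weaker inhibition:
compound 1 `O=C(O[C@H]1C[C@H](n2cc(F)c(=O)[nH]c2=O)O[C@@H]1COP(=O)(O)Oc1ccccc1)c1ccccc1` gives 1020 nM
compound 2 `CCOC(=O)C[n+]1cccc(OP(=O)([O-])OC[C@H]2O[C@@H](n3cc(F)c(=O)[nH]c3=O)C[C@@H]2OC(=O)c2ccccc2)c1` gives 2620 nM
compound 3 `O=c1[nH]c(=O)n([C@H]2C[C@H](O)[C@@H](COP(=O)(O)Oc3ccccc3)O2)cc1F` gives 26600 nM

Compound 3 stands highest of the three numbers in this assay; its nearest neighbour is compound 2 and its furthest is compound 1, both gaps beyond the scatter. Among the compounds with values here, the only single-place step in the set is a 26-fold higher number from compound 1 to compound 3 (1.42 log units; beyond the scatter), which concerns the oxygen on the saturated carbon and says nothing about the aryl on the oxygen whose other neighbour is phosphorus. Compound 4 `O=c1[nH]c(=O)n([C@H]2C[C@H](O)[C@@H](COP(=O)(O)Oc3ccc4ncccc4c3)O2)cc1F` differs from compound 3 only at that aryl: quinolin-6-yl in place of phenyl on an oxygen. Within the data shown here, no measured pair isolates a change at that oxygen; compound 2 carries a different aryl there but also keeps the benzoyl, so its value set against compound 1 or compound 3 cannot be read as a clean step. With nothing bearing on the change, the working expectation in this assay is no step beyond the scatter from compound 3 to compound 4, with the range widened for the lack of evidence, giving an expected 1.2-fold lower number from compound 3 to compound 4 (0.08 log units; within the scatter). Compound 4 is therefore estimated at 22000 nM, with a range of 7000 nM to 70000 nM.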

Compound 4, half-maximal inhibitory concentration: 1400 nM
Compound 4: the middle estimate sits 16-fold (1.20 log units) above what was measured; measured number below the stated range.
By their numbers in this assay, from the lowest: compounds 1, 4 and 2 (each within the scatter of the next, the first and the last beyond it); then compound 3.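

In this assay, the aryl on the oxygen whose other neighbour is phosphorus proves to be a working point of the series: quinolin-6-yl in place of phenyl gives a 19-fold lower number from compound 3 to compound 4 (1.28 log units; beyond the scatter) on the core that keeps hydrogen in place of benzoyl. Within the data shown here, until now the only clean reading came from the oxygen on the saturated carbon, where the step was a 26-fold higher number from compound 1 to compound 3 (1.42 log units; beyond the scatter) and the aryl stayed phenyl, so two separate places on the scaffold now each show a step beyond the scatter. The added ring carries one ring nitrogen and one hydrogen-bond acceptor, but nothing measured here links either feature to the lower number, and no available evidence accounts for the step.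

Still open, going by these compounds, is whether the ring nitrogen or the second ring carries the step, which a naphthyl group on the same oxygen would separate, as would an aminophenyl group for the role of the nitrogen. Also open, on these data alone, is how quinolin-6-yl behaves with benzoyl on the oxygen on the saturated carbon, since the two single-place steps have so far been seen only apart.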